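Heptyl for 1-ethylpentyl: what compound 4 should show

The compounds below may be only part of what the source reports. "The series", "measured", "known", "first", "only" and "open" are said of these compounds alone.

Of the compounds shown here, three have been measured so far in a physicochemical assay for lipophilicity, in phosphate buffer, measured as octanol-water partition, at pH 11.5; a higher number here means a more lipophilic compound, a lower number a more polar compound. Compound 2 `CCCCC(CC)CNC(=N)NC(=N)Nc1ccc(Cl)cc1` gives 4.93. Compound 1 `CCCCCCCCNC(=N)NC(=N)Nc1ccc(C)cc1` gives 4.93, level with compound 2 within the usual scatter of repeated measurements, so these two share the bottom of this small set. Compound 3 `CCCCCSc1ccc(NC(=N)NC(=N)NCCCCCCNC(=N)NC(=N)Nc2ccc(SCCCCC)cc2)cc1`, a much larger molecule, gives 8.58, well beyond that scatter from both.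

Compound 4 `CCCCCCCCNC(=N)NC(=N)Nc1ccc(Cl)cc1` has not yet been measured. It keeps every atom of compound 2 and only joins them differently: heptyl in place of 1-ethylpentyl on a saturated chain carbon bound to an amine nitrogen.

Within the data shown here, no pair of measured compounds shows this change on its own, so there is no direct precedent for its size. The closest clue has the same side chain as compound 4 and differs from it elsewhere: compound 1 gives 4.93. In this assay, only a small shift is therefore expected. The expected change, a number 0.07 log units higher from compound 2 to compound 4 (within the scatter), is a slight rise that stays within the scatter. For compound 4 the estimated value is 5, with an expected range from 4.7 to 5.35.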

Compound 4, partition coefficient: 5.13
Estimate against measurement, compound 4: 0.13 log units below; measured number inside the range.
By their numbers in this assay, from the lowest: compounds 1, 2 and 4 (each within the scatter of the next); then compound 3.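

In this assay, among these compounds, heptyl in place of 1-ethylpentyl on a saturated chain carbon bound to an amine nitrogen gives a number 0.20 log units higher from compound 2 to compound 4 (within the scatter) and this is the first direct view of that change: the atoms stay the same and only their joining differs, yet the step cannot be told apart from the spread of repeated measurements. Chloro in place of methyl on an aromatic carbon gives a number 0.20 log units higher from compound 1 to compound 4 (within the scatter) and this second single change, which swaps one group for a different one, likewise stays inside that spread. Compound 1, compound 2 and compound 4 therefore cannot be ranked against one another by this measurement, and neither change, seen here in one pair each, has a size that can be read.

As far as these compounds go, each change has been seen only once, so it remains open whether a longer chain or a cyclohexyl group at the chain position, or a methoxy group or a nitrile on the aromatic carbon, would give a step beyond the scatter. No supporting measurement is available to explain the size of either step.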